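The source may hold more compounds than are shown below. What is called first, only, known or untested is meant among the compounds shown, and "the series" means these compounds.

Three compounds of one series, all built on a shared core, have been measured so far. Compound 1 `O=C(Nc1ccccc1Cl)N1CCN(c2nc(-c3ccc4ccccc4n3)no2)CC1` gives 140 nM in a functional assay on Shh Light II cells (Mus musculus) for inhibition, read by a luciferase reporter; on this read-out lower numbers stand for stronger inhibition and higher numbers for weaker inhibition. Compound 2 `O=C(N1CCC(c2nc(-c3ccc4ccccc4n3)no2)CC1)N1CCCc2ccccc21` gives 2300 nM in this assay, and compound 3 `COc1ccccc1NC(=O)N1CCC(c2noc(-c3ccc4ccccc4n3)n2)CC1` gives 2400 nM. Among the three numbers compound 2 stands second highest; its value and that of compound 3 lie within the scatter of each other, so no order between those two can be stated, whereas compound 1 sits at a clearly lower number than compound 2.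

Compound 4 `O=C(Nc1ccccc1C(F)(F)F)N1CCC(c2nc(-c3ccc4ccccc4n3)no2)CC1` has not yet been measured. It differs from compound 2 in one place: (2-(trifluoromethyl)phenyl)amino in place of 1,2,3,4-tetrahydroquinolin-1-yl on a carbonyl carbon. The entering group brings one hydrogen-bond donor where the leaving group had none, a feature that compound 1 and compound 3 also carry on their urea, yet those two compounds give very different numbers, so the comparison does not settle the direction firmly. Going by the values given here, with no measured step of this kind to lean on, the step expected is a 3.8-fold lower number from compound 2 to compound 4 (0.58 log units; beyond the scatter), running towards a lower number yet stopping short of the gap to compound 1. Compound 4 is therefore estimated at 600 nM in this assay, with a range from 150 nM to 2500 nM.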

Compound 4, half-maximal inhibitory concentration: 700 nM
The estimate for compound 4 lay 1.2-fold (0.07 log units) below the measured number; the measured number falls inside the stated range.
By their numbers in this assay, from the lowest: compound 1; then compound 4; then compounds 2 and 3 (each within the scatter of the next).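

The group on the carbonyl carbon now has its first measured step in this assay: (2-(trifluoromethyl)phenyl)amino in place of 1,2,3,4-tetrahydroquinolin-1-yl gives a 3.3-fold lower number from compound 2 to compound 4 (0.52 log units; beyond the scatter). Going by these compounds alone, this shows that, with the rest of the molecule unchanged, the read-out responds to the group at this place, which the earlier compounds could not show because no two of them differed in one place only. The change, however, alters several things at once: a non-aromatic ring is lost, a trifluoromethyl group enters and a hydrogen-bond donor is gained, and nothing available bears on which of these accounts for the step.

The compounds shown leave open how the step divides between the trifluoromethyl group and the amino hydrogen, a question that a plain phenylamino group or an N-methyl-N-phenylamino group at the same place would address. They also leave open whether a nitrile or a methyl group in place of the trifluoromethyl group would give a number close to that of compound 4 700 nM.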